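The compounds below may be only part of what the source reports. "The series", "measured", "known", "first", "only" and "open" are said of these compounds alone.

Going by the values given here, in an assay on HEK293 cells for inhibition of N-acylethanolamine-hydrolyzing acid amidase (Homo sapiens), read by fluorescence, with stated times of 10 min and 50 min (a higher number here means a weaker inhibitor, a lower number a stronger inhibitor), compound 2 `O=C(N[C@H]1CNC1=O)OCCCCc1ccccc1` gives 1110 nM, the highest of the two numbers so far; compound 1 `CCCCCCCCOC(=O)N[C@H]1CNC1=O` gives 37 nM, and the change a 30-fold higher number from compound 1 to compound 2 (1.48 log units; beyond the scatter). Compound 3 `CCc1ccc(CCCCOC(=O)N[C@H]2CNC2=O)cc1` differs from compound 2 by ethyl in place of hydrogen on an aromatic carbon. Among the compounds with values here, no measured step carries the same change; the only step known, from compound 1 to compound 2, was large and ran toward weaker inhibition when the chain end was swapped. Extending the aromatic end with ethyl in compound 3 is therefore expected to give a 2.8-fold lower number from compound 2 to compound 3 (0.44 log units; beyond the scatter), a modest recovery. Compound 3 is expected at 400 nM, within 100 nM to 1600 nM.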

Compound 3, half-maximal inhibitory concentration: 230 nM
Beside the measured number, compound 3's estimate is 1.7-fold (0.24 log units) above it, and the stated range covers the measured number.
By their numbers in this assay, from the lowest: compound 1; then compound 3; then compound 2.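

In this assay, ethyl in place of hydrogen on an aromatic carbon, para to a large group, gives a 4.8-fold lower number from compound 2 to compound 3 (0.68 log units; beyond the scatter) and so recovers part of the loss seen in a 30-fold higher number from compound 1 to compound 2 (1.48 log units; beyond the scatter) without any change to the chain or the shared core. This is the first step shown on the ring itself, and it shows that this place responds to substitution, with the number moving toward stronger inhibition. Nothing at hand bears on why the number falls.

From the compounds shown here alone, what propyl, methoxy or an amine at this same place would give remains open. Also open, going by these compounds, is whether ethyl elsewhere on the ring would give a step of similar size.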